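The source may hold more compounds than are shown below. What is called first, only, known or untested is meant among the compounds shown, and "the series" means these compounds.

Measured compounds:
- compound 1, `C=CCn1c(=O)/c(=C\c2cccc(F)c2)[nH]c(=O)/c1=C\c1ccccc1OC` — 2500 nM
- compound 3, `COc1ccccc1/C=c1/[nH]c(=O)/c(=C\c2ccccc2OC)n(C)c1=O` — 1500 nM
- compound 2, `C=CCn1c(=O)/c(=C\c2cc(OC)c(OC)c(OC)c2)[nH]c(=O)/c1=C\c1cccc(Br)c1` — "not active" (no number reported)

In a functional assay on U-937 cells (Homo sapiens) for cytotoxicity, read by CCK-8 assay, with a stated time of 72 h (on this read-out lower numbers stand for stronger inhibition and higher numbers for weaker inhibition), compound 1 gives 2500 nM. Compound 3, with methyl rather than allyl on the shared core and a 2-methoxyphenyl at both arms, gives 1500 nM; compound 1 carries the higher of the two numbers, but the gap between compound 1 and compound 3 lies within the usual scatter of repeated measurements, so the two are not separated by these data. Compound 2 is reported as "not active" (no number reported), with no number given. Among the measured compounds shown here, no single-point step between measured compounds is available for this series.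

Compound 4, `C=CCn1c(=O)/c(=C\c2ccc(Cl)c(Cl)c2)[nH]c(=O)/c1=C\c1ccccc1OC`, is not yet measured. It differs from compound 1 in one place: 3,4-dichlorophenyl in place of 3-fluorophenyl on a double-bonded chain carbon bound to an aromatic carbon. Nothing in the measured set probes this exact exchange, so the expectation rests on the fact that compound 1 and compound 3 sit close together while compound 2, carrying a different pattern of aryl substitution, shows no activity. The step of a 1.3-fold lower number from compound 1 to compound 4 (0.10 log units; within the scatter) is therefore expected to be small, in either direction, and not clearly beyond the scatter. For compound 4 in this assay the estimate is 2000 nM, with a range from 700 nM to 7000 nM.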

Compound 4, half-maximal inhibitory concentration: "not active" (no number reported)
For compound 4 the study gives words and no number, and the estimate cannot be compared.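

Among the compounds shown here, compound 4, like compound 2, is reported in this assay in words and without a number, so no step from compound 1 to compound 4 can be read. The compounds shown leave open how 3,4-dichlorophenyl in place of 3-fluorophenyl acts on a numerical scale in this series. No evidence bears on this result.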